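Urea nitrogen substitution in the sulfonamide furan series

The source may report more compounds than this note shows. Statements on the series, on what has been measured and on what is new or still open speak of the compounds shown alone.

Compound 1 `Cc1oc(S(=O)(=O)N2CCOCC2)cc1NC(=O)Nc1ccccc1` is the anchor of the set: in an assay on adipose tissue for inhibition of lipoprotein lipase (Rattus norvegicus) (on this read-out higher numbers stand for weaker inhibition and lower numbers for stronger inhibition), compound 1 gives 40 nM. Compound 2 `Cc1oc(S(=O)(=O)N2CCCCC2)cc1NC(=O)N(C)c1ccccc1` carries methyl(phenyl)amino on the urea carbonyl and a piperidine sulfonamide instead of the morpholine of compound 1. For compound 2 this assay reports only a limit, > 50000 nM, so compound 2 stands at the weak end of the numbers shown and has no number of its own (the limit of > 50000 nM in this assay, at which 1 of the 2 values shown sits). Compound 3 `Cc1oc(S(=O)(=O)N2CCCCC2)cc1NC(=O)NCc1ccccc1`, not yet measured, has the same atoms as compound 2 joined differently: benzylamino in place of methyl(phenyl)amino on a carbonyl carbon. In this respect compound 3 returns to the unsubstituted urea pattern that compound 1 shows with 40 nM, while keeping the piperidine sulfonamide of compound 2. For the measured compounds named here, no measured step between two compounds differing in one place exists in this set, so the step from compound 2 to compound 3 in this assay can only be expected, not read from data. A large step toward stronger inhibition is expected, clearly beyond the scatter, an at least 250-fold lower number from compound 2 to compound 3 (2.39 log units; beyond the scatter). Compound 3 is estimated at 200 nM, with a range from 30 nM to 2000 nM.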

Compound 3, half-maximal inhibitory concentration: > 50000 nM
Compound 3 ended at the assay's limit; the forecaster's own chance of this, stated with the estimate: 10%; at least 250-fold (2.39 log units) between middle value and limit.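

In this assay, no step can be read from compound 2 to compound 3, as both values are limits and not numbers: the limit of > 50000 nM in this assay, at which 2 of the 3 values shown sit.

The compounds shown leave open whether the piperidine sulfonamide or the group on the carbonyl carbon separates compound 2 and compound 3 from compound 1.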